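The source may report more compounds than this note shows. Statements on the series, on what has been measured and on what is new or still open speak of the compounds shown alone.

In a functional assay on L1210 cells (Mus musculus) for antiproliferative activity, read by MTT assay, with a stated time of 72 h (on this read-out higher numbers stand for weaker inhibition and lower numbers for stronger inhibition), compound 1 `COc1cc(/C(=C/c2ccccc2)C(C)O)cc(OC)c1OC` reads > 100000 nM, which is a limit of the assay and not a number. Among the measured compounds shown here, compound 2 `COc1cc(/C(=C/c2ccc(C)cc2)C(C)O)cc(OC)c1OC` reads 33500 nM, the only true number so far. Methyl in place of hydrogen on an aromatic carbon gave an at least 2.9-fold lower number from compound 1 to compound 2 (0.47 log units; beyond the scatter), and this single measured step is only a loose guide for what comes next: it brought the methyl in, whereas now the methyl leaves. Compound 3 `COc1cc(/C(=C/c2ccc(Cl)cc2)C(C)O)cc(OC)c1OC` keeps the shared core but has chloro in place of methyl on an aromatic carbon, para to a large group: chloro in place of methyl on an aromatic carbon. For the measured compounds named here, no direction can be read from the one measured step, so the estimated change is a 1.1-fold lower number from compound 2 to compound 3 (0.05 log units; within the scatter), expected to stay within the scatter. The estimate for compound 3 is 30000 nM, with an expected range from 10000 nM to 90000 nM.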

Compound 3, half-maximal inhibitory concentration: > 100000 nM
Compound 3: no number, only a limit; the forecaster's own chance of this, stated with the estimate: 15%; middle value at least 3.3-fold (0.52 log units) away from the limit.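

In this assay, chloro in place of methyl gave an at least 2.9-fold higher number from compound 2 to compound 3 (0.47 log units; beyond the scatter), so this aromatic carbon responds even to a swap of one heavy atom for another, with no hydrogen-bond donor or acceptor on either side. Compound 3 reads > 100000 nM, a limit of the assay and not a number. Among the groups shown on this carbon, para to a large group, only the methyl of compound 2 gives a true number, while the hydrogen of compound 1 and the chloro of compound 3 do not.

On these data alone, the step between compound 1 and compound 3 cannot be read, and how far either compound lies past the limit stays unknown: the limit of > 100000 nM in this assay, at which 2 of the 3 values shown sit. Whether an amine, a carboxylic acid or a longer chain on this carbon would give a lower number than compound 2 stays open.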